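Methyl to methoxy in a weakly cytotoxic set

The source may hold more compounds than are shown below. What is called first, only, known or untested is meant among the compounds shown, and "the series" means these compounds.

In a functional assay on A549 cells (Homo sapiens) for cytotoxicity, read by MTT assay, with a stated time of 72 h (on this read-out lower numbers stand for stronger inhibition and higher numbers for weaker inhibition), the measured compounds stand as follows

- Compound 1 `COc1ccc(S(=O)(=O)c2nc3ccccc3nc2N2CCCC2)cc1` gives > 50000 nM as a limit
- Compound 2 `O=S(=O)(c1ccccc1)c1nc2ccccc2nc1N1CCc2ccccc2C1` gives 19800 nM as a number
- Compound 3 `Cc1ccc(S(=O)(=O)c2nc3ccccc3nc2N2CCc3ccccc3C2)cc1` gives > 50000 nM as a limit

Compound 3 stands at > 50000 nM as a limit and not as a number. The set shows the limit of > 50000 nM in this assay, at which 2 of the 3 values shown sit, and so gives no exact place for it.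

Compound 4 `COc1ccc(S(=O)(=O)c2nc3ccccc3nc2N2CCc3ccccc3C2)cc1` differs by methoxy in place of methyl on an aromatic carbon in one place: methoxy in place of methyl on an aromatic carbon, para to a large group. Going by the values given here, only one measured step touches this spot. It is an at least 2.5-fold higher number from compound 2 to compound 3 (0.40 log units; beyond the scatter) and it brings in methyl rather than methoxy, so it gives no size for this swap. Compound 1 also carries methoxy, and the expectation here leans on its > 50000 nM as a limit.

In this assay no step beyond the usual scatter is expected, so compound 4 should stay weak. The estimated change is a number no higher from compound 3 to compound 4 (the limit leaves the size open) in size. For compound 4 the estimated value is 50000 nM with an expected range of 18000 nM to 120000 nM for repeat measurements.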

Compound 4, half-maximal inhibitory concentration: > 50000 nM
Compound 4 gave a limit, no number; the forecaster's own chance of this, stated with the estimate: 60%; the middle value lies on the limit itself.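

At this position, para to a large group, methoxy in place of hydrogen gives an at least 2.5-fold higher number from compound 2 to compound 4 (0.40 log units; beyond the scatter), the same direction that methyl gave in compound 3. Compound 4 gives > 50000 nM in this assay, which is a limit and not a number. The steps from compound 3 and from compound 1 to compound 4 cannot be read, and the set now gathers at a single limit: the limit of > 50000 nM in this assay, at which 3 of the 4 values shown sit.

From the compounds shown here alone, how weak compound 3 and compound 4 truly are remains unknown, so methyl and methoxy cannot be ranked against each other here. Also open, going by these compounds, is whether a different group at this position, such as an amine or a carboxylic acid, would give a measurable number, and how that number would compare with compound 2, which gives 19800 nM.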